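Replacing a protected amine with butyl on a side chain

The source may hold more compounds than are shown below. What is called first, only, known or untested is meant among the compounds shown, and "the series" means these compounds.

In an ADME assay on NIH3T3 cells (Mus musculus) for cytotoxicity, read by crystal violet staining (on this read-out higher numbers stand for weaker inhibition and lower numbers for stronger inhibition), compound 1 `CCCCCCCC(NC(=O)CNC(=O)OCc1ccccc1)C(=O)NC1CCCCC1` gives 40000 nM and compound 2 `CCCCCCCC(NC(=O)CNC(=O)OCc1ccccc1)C(=O)NCc1ccccc1` gives 38000 nM. Going by the values given here, the step of a 1.1-fold lower number from compound 1 to compound 2 (0.02 log units; within the scatter) is the only measured step, and it touches the amide nitrogen rather than the side chain. Compound 3 `COc1ccc(CNC(=O)C(CCCCCNC(=O)OC(C)(C)C)NC(=O)CNC(=O)OCc2ccccc2)cc1` reaches only the limit of this assay, > 100000 nM, so its place is known solely as the limit of > 100000 nM in this assay, at which 1 of the 3 values shown sits, with no number attached. Compound 4 `CCCCCCCCCC(NC(=O)CNC(=O)OCc1ccccc1)C(=O)NCc1ccc(OC)cc1` differs from compound 3 by butyl in place of (tert-butoxycarbonyl)amino on a saturated chain carbon, six bonds along the chain from an amide-type nitrogen and a carbonyl carbon. Among the compounds with values here, no measured step covers this change, so the step from compound 1 to compound 2 is the only guide, and it was within the scatter. What the values show is that compound 1 and compound 2, both carrying a plain alkyl side chain, sit near the same number in this assay, while compound 3, carrying the protected amine, gives only a limit. On that basis compound 4 is expected to land near the numbers of compound 1 and compound 2, with an at least 2.5-fold lower number from compound 3 to compound 4 (0.39 log units; beyond the scatter) taken as the estimated step. The estimate for compound 4 in this assay is 40000 nM, within 15000 nM to 100000 nM.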

Compound 4, half-maximal inhibitory concentration: 55000 nM
The estimate for compound 4 lay 1.4-fold (0.14 log units) below the measured number; the range from low to high includes it.
By their numbers in this assay, from the lowest: compounds 2, 1 and 4 (each within the scatter of the next). At a limit, above all of these: compound 3.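

In this assay, the exchange of (tert-butoxycarbonyl)amino for butyl on this saturated chain carbon now has a reading of its own: the change gives an at least 1.8-fold lower number from compound 3 to compound 4 (0.25 log units; that floor lies within the scatter). This is the only step shown at this position, and it fixes a floor rather than a size, so the reading neither establishes a real difference nor rules out a large one. The true size stays unresolved on the upper side, as compound 3 gives only a limit: the limit of > 100000 nM in this assay, at which 1 of the 4 values shown sits.

The compounds shown leave open how a free amine, a carboxylic acid or a longer chain on this carbon would read in this assay. They also leave open whether butyl and (tert-butoxycarbonyl)amino would differ by more than the scatter on a read-out that gives compound 3 a number.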